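Removing the (benzyloxy)methyl group from compound 1

This account rests on a few compounds, and the source may have more. Where it says the series, first, only, none or still open, it means among the compounds named here.

In a functional assay on BGC-823 cells (Homo sapiens) for inhibition, read by MTT assay, with a stated time of 72 h (a higher number here means a weaker inhibitor, a lower number a stronger inhibitor), compound 1 (`O=C1/C(=C\c2ccccc2)c2c(ncn2COCc2ccccc2)CCN1Cc1ccccc1`) gives 20400 nM as its half-maximal inhibitory concentration. In the same test compound 2 (`Cc1cccc(CN2CCc3ncn(COCc4ccccc4)c3/C(=C/c3ccccc3)C2=O)c1`) gives 14600 nM and compound 3 (`COc1ccc(CN2CCc3ncn(COCc4ccccc4)c3/C(=C/c3ccccc3)C2=O)cc1`) gives 71600 nM as its result. Compound 1 therefore cannot be told apart from compound 2, with a 1.4-fold lower number from compound 1 to compound 2 (0.15 log units; within the scatter) on record, while the gap to compound 3 is real, at a 3.5-fold higher number from compound 1 to compound 3 (0.55 log units; beyond the scatter) on the same scale.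

Compound 4 (`O=C1/C(=C\c2ccccc2)c2[nH]cnc2CCN1Cc1ccccc1`) differs from compound 1 elsewhere in the molecule, with hydrogen in place of (benzyloxy)methyl on an aromatic nitrogen. The change in full is hydrogen in place of (benzyloxy)methyl on an aromatic nitrogen and nothing else moves.

Among the compounds with values here, all three measured compounds keep the (benzyloxy)methyl group, so no measured step shows directly what losing it does. The steps offer only a sense of scale. The largest, a 4.9-fold higher number from compound 2 to compound 3 (0.69 log units; beyond the scatter) in size, comes from altering the benzyl group on the amide-type nitrogen, a smaller edit than this one. A modest move towards a higher number, meaning a weaker inhibitor, is expected, with real uncertainty about its direction. The estimated change is a 2.0-fold higher number from compound 1 to compound 4 (0.29 log units; within the scatter) in this series. For compound 4 the expected value is 40000 nM with an estimated range from 13000 nM to 120000 nM in this test.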

Compound 4, half-maximal inhibitory concentration: > 100000 nM
Compound 4: a limit, no number; the forecaster's own chance of this, stated with the estimate: 20%; at least 2.5-fold (0.39 log units) between middle value and limit.
By their numbers in this assay, from the lowest: compounds 2 and 1 (each within the scatter of the next); then compound 3. At a limit, above all of these: compound 4.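

Compound 4 gives no number, only a limit of the test: the limit of > 100000 nM in this assay, at which 1 of the 4 values shown sits. Within the data shown here, the earlier compounds all keep the (benzyloxy)methyl group and differ only elsewhere in the molecule, so this is the first direct look at the aromatic nitrogen, and placing hydrogen there in place of that group gives an at least 4.9-fold higher number from compound 1 to compound 4 (0.69 log units; beyond the scatter), a step that is itself bounded by the limit. Among these compounds, in this single pair, then, the group cannot be dropped without the inhibitor becoming weaker in this assay, and the change is at least as large as any step among the earlier compounds, although it says nothing about which part of the group counts.

As far as these compounds go, how much of the (benzyloxy)methyl group matters remains open: a plain methyl or a benzyl on the same aromatic nitrogen, or a longer chain ending in the same aromatic ring, would separate the presence of any group there from the part played by its oxygen and its ring. Also open, from the compounds shown here alone, is whether an amine or a carboxylic acid at the end of such a chain would keep the inhibition seen for compound 1.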